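This account rests on a few compounds, and the source may have more. Where it says the series, first, only, none or still open, it means among the compounds named here.

In a functional assay on MCF7 cells (Homo sapiens) for cytotoxicity, read by MTT assay, with a stated time of 24 h; a lower number here means a stronger inhibitor, a higher number a weaker inhibitor:
compound 1, `Cc1cc(O)c(C(=O)/C=C/c2ccc(F)cc2)c(-c2ccccc2)c1C(=O)/C=C/c1ccc(F)cc1`: 20000 nM
compound 2, `Cc1cc(O)c(C(=O)/C=C/c2ccc(Cl)cc2)c(-c2ccccc2)c1C(=O)/C=C/c1ccc(Cl)cc1`: 10000 nM

Compound 2 has the lowest number of the two in this assay. The nearest is compound 1 at 20000 nM; compound 2 itself stands at 10000 nM, and the gap between the two sits within the scatter of repeated measurements, so no order can be read from it. Among the measured compounds shown here, no pair of measured compounds that differ in one place is available, and the two measured compounds differ in the halogen on both cinnamoyl arms at once.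

Compound 3, `Cc1cc(O)c(C(=O)/C=C/c2ccc(Cl)cc2)c(-c2ccc(Br)cc2)c1C(=O)/C=C/c1ccc(Cl)cc1`, has not been measured in this assay. Against compound 2 the change is bromo in place of hydrogen on an aromatic carbon. For the measured compounds named here, nothing in the measured set isolates a change of this kind, so the size of the step has no direct precedent here. The expectation is a modest step toward a lower number, of a size not clearly beyond the scatter. For compound 3 the estimate is 7000 nM, within 2500 nM to 20000 nM. The expected step from compound 2 to compound 3 is a 1.4-fold lower number from compound 2 to compound 3 (0.15 log units; within the scatter).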

Compound 3, half-maximal inhibitory concentration: 20000 nM
Estimate against measurement, compound 3: 2.9-fold (0.46 log units) below, and the stated range covers the measured number.
By their numbers in this assay, from the lowest: compounds 2, 1 and 3 (each within the scatter of the next).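

In this assay, among the compounds shown here, phenyl to 4-bromophenyl on the shared core gives a 2.0-fold higher number from compound 2 to compound 3 (0.30 log units; within the scatter), and this is the only single-place step the series offers so far. It shows that bromo in place of hydrogen, on an aromatic carbon para to a large group, leaves compound 2 and compound 3 indistinguishable in this read-out, whereas the earlier pair changed the halogen on both cinnamoyl arms at once and said nothing about this ring. No measured information on the compounds accounts for this outcome, and a step within the scatter offers little to account for.

Still open, going by these compounds, is whether a different group at this same place, such as an amine, a carboxylic acid or a methoxy group, would give a step beyond the scatter, or whether this position stays flat across substituents of other kinds. Also open, on these data alone, is whether the phenyl to 4-bromophenyl change reads the same with the fluoro arms of compound 1, and how each cinnamoyl arm contributes when its halogen is changed alone.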